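Removing the Methylsulfonyl Piperazine from Compound 3

A few compounds are considered here, and "the series" means these few. Any claim that something is new, unique, unknown or untested is made for them only; others in the source may bear on it.

compound 1 (`COc1cc(OC)c(Cl)c(-c2ccc3c(NC(=O)c4ccc(N5CCCN(C)CC5)cc4)n[nH]c3n2)c1Cl`): 1.3 nM
compound 2 (`COc1cc(OC)c(Cl)c(-c2ccc3c(NC(=O)c4ccc(N5CCN(C(C)=O)CC5)cc4)n[nH]c3n2)c1Cl`): 43.3 nM
compound 3 (`COc1cc(OC)c(Cl)c(-c2ccc3c(NC(=O)c4ccc(N5CCN(S(C)(=O)=O)CC5)cc4)n[nH]c3n2)c1Cl`): 245 nM

These values come from a functional assay on NCI-H1581 cells (Homo sapiens) for antiproliferative activity, read by CCK-8 assay, with a stated time of 72 h (a higher number here means a weaker inhibitor, a lower number a stronger inhibitor), and they share one core, varying only in the group on the benzene-type ring of carbon. Compound 3 has the highest number of the three, which makes it the weakest inhibitor here.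

Compound 4 (`COc1cc(OC)c(Cl)c(-c2ccc3c(NC(=O)c4ccc(N(C)CCN(C)C)cc4)n[nH]c3n2)c1Cl`) carries (2-(dimethylamino)ethyl)(methyl)amino in place of 4-(methylsulfonyl)piperazin-1-yl on an aromatic carbon. Going by the values given here, three measured steps bear on this change. The largest is a 190-fold higher number from compound 1 to compound 3 (2.28 log units; beyond the scatter) and a smaller one is a 33-fold higher number from compound 1 to compound 2 (1.52 log units; beyond the scatter), while swapping the end group alone gave a 5.7-fold higher number from compound 2 to compound 3 (0.75 log units; beyond the scatter). Among the compounds with values here, the entering group has no acetyl or methylsulfonyl, like the 4-methyl-1,4-diazepan-1-yl of compound 1 (1.3 nM), but it has no ring, and no measured compound tests that. A large fall in the number is therefore expected, with an estimated 61-fold lower number from compound 3 to compound 4 (1.79 log units; beyond the scatter). For compound 4 the estimated value is 4 nM, with an expected range of 1 nM to 25 nM.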

Compound 4, half-maximal inhibitory concentration: 11 nM
Beside the measured number, compound 4's estimate is 2.8-fold (0.44 log units) below it; the measured number falls inside the stated range.
By their numbers in this assay, from the lowest: compound 1; then compound 4; then compound 2; then compound 3.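

Replacing the 4-(methylsulfonyl)piperazin-1-yl with the open (2-(dimethylamino)ethyl)(methyl)amino chain gives a clear gain (a 22-fold lower number from compound 3 to compound 4 (1.35 log units; beyond the scatter)), and the chain also improves on the 4-acetylpiperazin-1-yl of compound 2 (a 3.9-fold lower number from compound 2 to compound 4 (0.60 log units; beyond the scatter)), so a low number at this position does not require a ring. Even so, the chain does not match the 4-methyl-1,4-diazepan-1-yl, as the comparison with compound 1 shows (an 8.5-fold higher number from compound 1 to compound 4 (0.93 log units; beyond the scatter)). Nothing available here explains these differences.

A 4-methylpiperazin-1-yl, with a plain methyl in place of the acetyl or methylsulfonyl, would help separate the effect of the end group from that of the ring. As far as these compounds go, it also remains open how a longer chain between the two nitrogens, or a morpholine, would compare.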